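Aryl triazole esters of a hydroxylated terpenoid scaffold

The source may report more compounds than this note shows. Statements on the series, on what has been measured and on what is new or still open speak of the compounds shown alone.

Measured compounds in a functional assay on A549 cells (Homo sapiens) for antiproliferative activity, read by MTT assay, with a stated time of 48 h; on this read-out higher numbers stand for weaker inhibition and lower numbers for stronger inhibition:
- compound 1, `C#CCOC(=O)/C(C)=C/CC/C(C)=C/CC/C(C)=C/CC[C@@H]1[C@@]2(C)CCC(=O)C(C)(C)[C@H]2CC[C@@]1(C)O`: 45100 nM
- compound 2, `C/C(=C\CC/C(C)=C/CC[C@@H]1[C@@]2(C)CCC(=O)C(C)(C)[C@H]2CC[C@@]1(C)O)CC/C=C(\C)C(=O)OCc1cn([C@@H]2C[C@@H](n3cc(C)c(=O)[nH]c3=O)O[C@H]2CO)nn1`: 35000 nM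
- compound 3, `C/C(=C\CC/C(C)=C/CC[C@@H]1[C@@]2(C)CCC(=O)C(C)(C)[C@H]2CC[C@@]1(C)O)CC/C=C(\C)C(=O)OCc1cn(-c2ccc(Cl)cc2)nn1`: a limit of the assay, > 150000 nM

Compound 1 and compound 2 give numbers that sit within the usual scatter of each other, so neither can be called the stronger. Compound 3 gives only a limit, as noted in the limit of > 150000 nM in this assay, at which 1 of the 3 values shown sits; the assay reports no number for it.

Compound 4, `C/C(=C\CC/C(C)=C/CC[C@@H]1[C@@]2(C)CCC(=O)C(C)(C)[C@H]2CC[C@@]1(C)O)CC/C=C(\C)C(=O)OCc1cn(-c2ccccc2F)nn1`, differs from compound 1 by 1-(2-fluorophenyl)-1H-1,2,3-triazol-4-yl in place of ethynyl on a saturated chain carbon bound to an oxygen next to a carbonyl group.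

Within the data shown here, one measured step bears on this change. Replacing the ethynyl group with a 1-(4-chlorophenyl)-1H-1,2,3-triazol-4-yl group gave an at least 3.3-fold higher number from compound 1 to compound 3 (0.52 log units; beyond the scatter), and the new group in compound 4 is likewise an aryl triazole, differing only in its halogen and where that halogen sits on the phenyl ring. A step to weaker inhibition in this assay is therefore expected, of a size comparable to that step, with a real chance that the assay again reports only a limit.

Compound 4 is thus estimated to give 120000 nM, between 45000 nM and 300000 nM, which means an expected 2.7-fold higher number from compound 1 to compound 4 (0.43 log units; beyond the scatter).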

Compound 4, half-maximal inhibitory concentration: > 150000 nM
Compound 4 ended at the assay's limit; the forecaster's own chance of this, stated with the estimate: 45%; middle value at least 1.2-fold (0.09 log units) from the limit.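

Putting the 1-(2-fluorophenyl)-1H-1,2,3-triazol-4-yl group in place of ethynyl gave an at least 3.3-fold higher number from compound 1 to compound 4 (0.52 log units; beyond the scatter) in this assay, a step that rests on a limit of the assay rather than a number. A second aryl triazole, with a different halogen at a different place on the phenyl ring, therefore also loses activity, so the loss is not peculiar to the 4-chlorophenyl group of compound 3. The step from compound 3 to compound 4 cannot be read, so these two aryl groups cannot be ranked, and both compounds now share one limit: the limit of > 150000 nM in this assay, at which 2 of the 4 values shown sit.

On these data alone, the true numbers of compound 3 and compound 4 remain unknown. Also open, as far as these compounds go, is whether a plain phenyl, or a phenyl ring carrying an amine or a carboxylic acid, would bring the triazole esters back to a measurable number in this assay.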